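The source may report more compounds than this note shows. Statements on the series, on what has been measured and on what is new or still open speak of the compounds shown alone.

Measured so far:
- Compound 1, `CCNS(=O)(=O)CCNc1nonc1/C(=N/O)Nc1ccc(F)c(Br)c1`: 95 nM
- Compound 2, `O=S(=O)(CCNc1nonc1/C(=N/O)Nc1ccc(F)c(Br)c1)NCC1CC1`: 312 nM

Among the measured compounds shown here, compound 2 carries the higher of the two numbers in an assay on isolated protein for inhibition of Indoleamine 2,3-dioxygenase 1 (Homo sapiens), read by fluorescence, with a stated time of 60 min; a higher number here means a weaker inhibitor, a lower number a stronger inhibitor; the only neighbour, compound 1, sits at a lower value, and the one step measured, a 3.3-fold higher number from compound 1 to compound 2 (0.52 log units; beyond the scatter), lies beyond the scatter. Compound 3, `NS(=O)(=O)CCCNc1nonc1/C(=N/O)Nc1ccc(F)c(Br)c1`, has not yet been measured. It differs from compound 2 by sulfamoylmethyl in place of (cyclopropylmethyl)sulfamoyl on a saturated chain carbon, two bonds along the chain from a nitrogen on an aromatic ring. For the measured compounds named here, the step from compound 1 to compound 2 bears on this change only in part: it shows that enlarging the group on the sulfonamide nitrogen weakened inhibition, and compound 3 moves the other way, to an unsubstituted sulfonamide, while also lengthening the chain, for which no measured step exists. On that basis the step of a 3.9-fold lower number from compound 2 to compound 3 (0.59 log units; beyond the scatter) is expected to run toward a lower number, at least back to the neighbourhood of compound 1. Compound 3 is therefore estimated at 80 nM, with a range from 25 nM to 300 nM.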

Compound 3, half-maximal inhibitory concentration: 126 nM
Estimate against measurement, compound 3: 1.6-fold (0.20 log units) below, within the range that was stated.
By their numbers in this assay, from the lowest: compounds 1 and 3 (each within the scatter of the next); then compound 2.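

Putting sulfamoylmethyl in place of (cyclopropylmethyl)sulfamoyl on this saturated chain carbon gives a 2.5-fold lower number from compound 2 to compound 3 (0.39 log units; beyond the scatter) in this assay, so this position tolerates a sulfonamide with no substituent on its nitrogen. Set against ethylsulfamoyl, the same group gives a 1.3-fold higher number from compound 1 to compound 3 (0.12 log units; within the scatter), so compound 1 and compound 3 cannot be told apart in this assay, and the change from ethylsulfamoyl to sulfamoylmethyl shows no measurable effect on inhibition here. Nothing available explains either step.

Both steps alter the sulfonamide nitrogen and the chain together, so the share of each change remains unresolved. Also open, on these data alone, is how a carboxylic acid or an amine would read in place of the sulfonamide, and how a longer chain would read.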